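Tolyl to chlorophenyl sulfonamide: expected effect on inhibition

The source may report more compounds than this note shows. Statements on the series, on what has been measured and on what is new or still open speak of the compounds shown alone.

Compound 1 `Cc1ccc(S(=O)(=O)Nc2cccc(-c3ccc(C(=O)c4cc(F)c(F)c(O)c4F)s3)c2)cc1` gives 30% in an assay on HEK293 cells for inhibition of 17-beta-hydroxysteroid dehydrogenase type 1 (Mus musculus), read by HPLC, tested at 500 nM, in the presence of a further agent that is not named here; a higher number here means more inhibition at the concentration tested (going by the name of the read-out), a lower number less inhibition. Among the three measured compounds it stands second highest; compound 3 `O=C(c1ccc(-c2cccc(NS(=O)(=O)c3ccccc3)c2)s1)c1cccc(O)c1Cl` gives 26%, within the scatter of compound 1, while compound 2 `Cc1cccc(S(=O)(=O)Nc2cccc(-c3ccc(C(=O)c4cc(F)c(F)c(O)c4F)s3)c2)c1` gives 49%, the only compound set apart from it beyond the scatter.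

The new compound 4 `O=C(c1ccc(-c2cccc(NS(=O)(=O)c3ccc(Cl)cc3)c2)s1)c1cc(F)c(F)c(O)c1F` differs from compound 1 by chloro in place of methyl on an aromatic carbon. Among the compounds with values here, the only measured step, a number 19 percentage points higher from compound 1 to compound 2 (beyond the scatter), moves the methyl from one aromatic carbon to another without exchanging it for a different group; it shows that this part of the molecule can shift the read-out by a modest amount, but it does not test chloro against methyl. Compound 3 carries no substituent on that ring yet also differs elsewhere, so its value gives no clean reading either. Within the data shown here, with no directly comparable step, the expectation for this assay is a step of no clear direction and within the scatter.

Compound 4 is therefore estimated at 32% (range 15% to 55%), which means an expected step of a number 2 percentage points higher from compound 1 to compound 4 (within the scatter).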

Compound 4, a percentage reported as inhibition, at one concentration (the size of the read-out at that concentration, not a potency): 31%
For compound 4 the middle estimate is 1 percentage points above the measured one; the measured number falls inside the stated range.
By their numbers in this assay, from the lowest: compounds 3, 1 and 4 (each within the scatter of the next); then compound 2.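

In this assay, 4-chlorophenyl in place of 4-methylphenyl gives a number 1 percentage points higher from compound 1 to compound 4 (within the scatter) and so does not separate chloro from methyl at this position, para to a large group. The step of a number 18 percentage points lower from compound 2 to compound 4 (beyond the scatter) shows that compound 4 stays apart from the 3-methylphenyl compound, so among these compounds, the only step beyond the scatter from a 4-substituted ring is to that 3-methylphenyl compound, with chloro and methyl alike in the 4-substituted pair. Nothing at hand explains either step.

Open, from the compounds shown here alone, is whether a 3-chlorophenyl on the sulfonyl sulfur would stand with compound 2 or with compound 4. Also open, going by these compounds, is whether an amine or a carboxylic acid in place of the chloro of compound 4 would move the read-out in this assay at all.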